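Thiophene to pyridine on a fused bicyclic dihydropyridine series

This account rests on a few compounds, and the source may have more. Where it says the series, first, only, none or still open, it means among the compounds named here.

Compound 1 `CCOC(=O)C1=C(C)NC(C)=C(C(=O)OCC)C1c1c(-c2cc(OC)ccc2OC)nc2sccn12`: 2630 nM in a functional assay on cardiac atrium (Cavia porcellus); a lower number here means that less compound is needed, a higher number that more compound is needed for the effect
Compound 2 `COC(=O)C1=C(C)NC(C)=C(C(=O)OC)C1c1c(-c2cccs2)nc2sccn12`: 1300 nM
Compound 3 `COC(=O)C1=C(C)NC(C)=C(C(=O)OC)C1c1c(-c2cccs2)nc2sc(C)cn12`: 40500 nM

Compound 3 stands at the highest number of the three, its nearest neighbour being compound 1 and its furthest compound 2. Within the data shown here, the one measured step, a 31-fold higher number from compound 2 to compound 3 (1.49 log units; beyond the scatter), concerns a different place and does not bear on the change now considered. Compound 4 `COC(=O)C1=C(C)NC(C)=C(C(=O)OC)C1c1c(-c2cccnc2)nc2sc(C)cn12` differs from compound 3 by pyridin-3-yl in place of thiophen-2-yl on an aromatic carbon. Among the measured compounds shown here, no measured pair shows this exchange, so the expectation rests on compound 3 alone, with a wide range and no direction beyond the scatter. Compound 4 is expected to give 30000 nM, between 8000 nM and 120000 nM. The step this estimate means is expected to be a 1.4-fold lower number from compound 3 to compound 4 (0.13 log units; within the scatter).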

Compound 4, half-maximal effective concentration: 12500 nM
For compound 4 the middle estimate is 2.4-fold (0.38 log units) above the measured one, and the stated range covers the measured number.
By their numbers in this assay, from the lowest: compound 2; then compound 1; then compound 4; then compound 3.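

Among these compounds, the exchange of thiophen-2-yl for pyridin-3-yl gives a 3.2-fold lower number from compound 3 to compound 4 (0.51 log units; beyond the scatter) in this assay and is the first change at this aromatic carbon read with all else held constant. It shows that the read-out depends on the ring at this place, even with the methyl of compound 3 retained. Nothing available explains this step.

On these data alone, it remains open whether the exchange would act alike on the core of compound 2, which lacks that methyl. As far as these compounds go, how a plain phenyl ring or a pyridin-4-yl ring would read at this carbon also remains open.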